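The source may hold more compounds than are shown below. What is called first, only, known or untested is meant among the compounds shown, and "the series" means these compounds.

Measured so far:
Compound 1, `Cc1ccc(NC(=O)Nc2cccc(CNc3nccnc3Cl)c2)cc1Cl`: 11300 nM
Compound 2, `Cc1ccc(NC(=O)Nc2cccc(CNc3nccnc3Cl)c2)c(C)c1`: 9290 nM

Both compounds share a core and differ only in the aryl group on the urea nitrogen. In a functional assay on HepG2 cells (Homo sapiens) for antiproliferative activity, read by MTT assay, with a stated time of 48 h (on this read-out lower numbers stand for stronger inhibition and higher numbers for weaker inhibition), compound 1 gives 11300 nM and compound 2 gives 9290 nM. Among the compounds with values here, the single step of a 1.2-fold lower number from compound 1 to compound 2 (0.09 log units; within the scatter) does not separate the two, so compound 2 cannot be set apart from compound 1 on these numbers; it simply sits with its neighbour within the scatter.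

Compound 3, `COc1ccc(NC(=O)Nc2cccc(CNc3nccnc3Cl)c2)cc1`, carries a further variation at the same place: 4-methoxyphenyl in place of 2,4-dimethylphenyl on an amide-type nitrogen. Within the data shown here, the only measured step that bears on this change is the exchange of one aryl group for another on that nitrogen, a 1.2-fold lower number from compound 1 to compound 2 (0.09 log units; within the scatter), which stayed within the scatter. Among the measured compounds shown here, nothing among the measured compounds shows an aryl exchange at this position moving the number beyond the scatter, so compound 3 is expected to show no step of note, a 1.1-fold higher number from compound 2 to compound 3 (0.03 log units; within the scatter). Compound 3 is therefore estimated at 10000 nM, with a range from 4000 nM to 25000 nM.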

Compound 3, half-maximal inhibitory concentration: 12000 nM
Compound 3: the middle estimate sits 1.2-fold (0.08 log units) below what was measured; measured number inside the range.
By their numbers in this assay, from the lowest: compounds 2, 1 and 3 (each within the scatter of the next).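

In this assay, the 4-methoxyphenyl group of compound 3 brings an oxygen to this amide-type nitrogen's aryl group and, with it, 1 hydrogen-bond acceptor, where 2,4-dimethylphenyl has 0. This exchange still gives only a 1.3-fold higher number from compound 2 to compound 3 (0.11 log units; within the scatter) and the exchange for 3-chloro-4-methylphenyl gives a 1.1-fold higher number from compound 1 to compound 3 (0.03 log units; within the scatter) so the three aryl groups cannot be told apart on these numbers, even with an oxygen-bearing group among them. No measurement is at hand that would offer an explanation for this result.

Going by these compounds, all three compounds keep an aryl group with small substituents at this place, so it remains open whether a carboxylic acid or an amine on that ring, or a cyclohexyl group or a longer alkyl chain in place of the ring, would move the number beyond the scatter. The shared core is also the same throughout, which leaves open what would follow from changing any part of it, for instance putting an amine in place of its chlorine.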